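This account rests on a few compounds, and the source may have more. Where it says the series, first, only, none or still open, it means among the compounds named here.

Within the data shown here, compound 2, `COc1ccc(CNCCCNS(=O)(=O)c2cc(C(F)(F)F)cc(C(F)(F)F)c2)cc1OC`, is the compound with the lowest of the two numbers so far in a functional assay on MCF7 cells (Homo sapiens) for inhibition, read by MTT assay, with a stated time of 72 h (a higher number here means a weaker inhibitor of growth, a lower number a stronger inhibitor of growth), where compound 2 gives 1900 nM. Among the measured compounds shown here, its only neighbour on the same ring is compound 1, `O=S(=O)(NCCCNCc1ccc(Cl)cc1)c1cc(C(F)(F)F)cc(C(F)(F)F)c1`, which in this assay gives 2400 nM; the change along that step, a 1.3-fold lower number from compound 1 to compound 2 (0.10 log units; within the scatter), replaced the 4-chlorophenyl by a 3,4-dimethoxyphenyl and left the number within the scatter.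

Compound 3, `COc1cccc(CNCCCNS(=O)(=O)c2cc(C(F)(F)F)cc(C(F)(F)F)c2)c1`, follows from compound 2 by a smaller change on the same ring: hydrogen in place of methoxy on an aromatic carbon. For the measured compounds named here, the one measured step that touches this ring, from compound 1 to compound 2, swapped the whole substitution pattern and still stayed within the scatter, so the numbers give no sign that this ring governs growth inhibition strongly. Going by the values given here, with only that step as a guide, no step beyond the scatter is expected in this assay from the loss of one methoxy group. Compound 3 is therefore expected to give 2100 nM, with a range from 800 nM to 5500 nM, which would mean a step of a 1.1-fold higher number from compound 2 to compound 3 (0.04 log units; within the scatter).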

Compound 3, concentration for 50% growth inhibition: 2400 nM
For compound 3 the middle estimate is 1.1-fold (0.06 log units) below the measured one, and the stated range covers the measured number.
By their numbers in this assay, from the lowest: compounds 2, 1 and 3 (each within the scatter of the next).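

In this assay, hydrogen in place of the methoxy group that stands ortho to a methoxy group and para to a large group gives a 1.3-fold higher number from compound 2 to compound 3 (0.10 log units; within the scatter), so this one position, changed on its own, moves the number no further than the scatter. The earlier step had changed the whole substitution pattern at once, and it could not show what a single methoxy group contributes. The other new step, no change at the digits printed from compound 1 to compound 3 (within the scatter), places the 3-methoxyphenyl level with the 4-chlorophenyl, so among these three compounds the 4-chlorophenyl, 3,4-dimethoxyphenyl and 3-methoxyphenyl rings all lie within the scatter of one another. Nothing available here bears on why these ring changes leave the number where it is.

The compounds shown leave open whether a different kind of group on this ring, such as a carboxylic acid or an amine, would give a step beyond the scatter. All three also share the rest of the core, so they cannot tell whether a longer chain in place of the shared one, or another group in place of either trifluoromethyl, would matter more than the ring does.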